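Shortening the Chain on the Nitrile-Bearing Core

The source may report more compounds than this note shows. Statements on the series, on what has been measured and on what is new or still open speak of the compounds shown alone.

Among the three compounds measured so far, compound 3 `CCCc1cnc2c(C#N)c(N3CCN(c4nc(C)cc(C)n4)CC3)ccn12` stands second in a functional assay on CHO cells with metabotropic glutamate receptor 2 (Homo sapiens) as the target, read by GTPgammaS binding (on this read-out lower numbers stand for smaller maximal responses and higher numbers for larger maximal responses), with 179%. Compound 2 `CCCc1cnc2c(C#N)c(N3CCN(c4ncccn4)CC3)ccn12` gives 248%, and compound 1 `Cc1cc(C)nc(N2CCN(c3ccn4c(CC(F)(F)F)cnc4c3C#N)CC2)n1` gives 128%. Both measured steps were large: a number 51 percentage points higher from compound 1 to compound 3 (beyond the scatter) and a number 69 percentage points lower from compound 2 to compound 3 (beyond the scatter). Compound 4 `CCc1cnc2c(C#N)c(N3CCN(c4nc(C)cc(C)n4)CC3)ccn12` differs from compound 3 by hydrogen in place of methyl on a saturated chain carbon, two bonds along the chain from an aromatic carbon. Among the measured compounds shown here, only the step from compound 1 to compound 3 concerns the same chain, and it altered a different part of it, so it bears only loosely on this change; no measured step shortens the chain in the same way. A modest downward step is therefore expected, a number 14 percentage points lower from compound 3 to compound 4 (beyond the scatter), though an outcome within the scatter would not surprise. Compound 4 is estimated to give 165%, within 125% to 205%.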

Compound 4, largest response reached (Emax), in percent of the reference or control that the assay uses: 142%
Compound 4: middle estimate off by 23 percentage points, on the high side; measured number inside the range.
By their numbers in this assay, from the lowest: compound 1; then compound 4; then compound 3; then compound 2.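

In this assay, shortening propyl to ethyl is a large step, a number 37 percentage points lower from compound 3 to compound 4 (beyond the scatter), so the number at this position changes measurably with one carbon on the chain. Methyl in place of trifluoromethyl on the saturated chain carbon bound to an aromatic carbon gives only a modest step, a number 14 percentage points higher from compound 1 to compound 4 (beyond the scatter). No evidence is available that accounts for either step. Going by these compounds, whether a longer chain such as butyl or a branched chain such as isopropyl would raise the number further remains open. So does whether shortening the chain has a similar effect with pyrimidin-2-yl on the amine nitrogen.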